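Swapping Chloro for Methyl in a Weak Compound

The compounds below may be only part of what the source reports. "The series", "measured", "known", "first", "only" and "open" are said of these compounds alone.

In a functional assay on A549 cells (Homo sapiens) for antiproliferative activity, read by CCK-8 assay, with a stated time of 72 h (a lower number here means a stronger inhibitor, a higher number a weaker inhibitor), compound 1 `C/C(=N\O)c1ccc(OCc2ccc(C(=O)NO)cc2)cc1` gives 8930 nM. In this assay, compound 2 `Nc1ccccc1NC(=O)c1ccc(COc2ccc(Cl)cc2)cc1` reads only as a limit, > 32000 nM, not as an exact number. Compound 3 `Cc1ccc(OCc2ccc(C(=O)Nc3ccccc3N)cc2)cc1` differs from compound 2 in one place: methyl in place of chloro on an aromatic carbon. This puts methyl in place of chloro on an aromatic carbon. Among the measured compounds shown here, no measured pair here shows what this swap does, so no change beyond the usual scatter is expected, in either direction. The estimated step of a number no higher from compound 2 to compound 3 (the limit leaves the size open) is therefore small. Compound 3 is expected near 32000 nM, with an estimated range of 12000 nM to 64000 nM.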

Compound 3, half-maximal inhibitory concentration: 5430 nM
The estimate for compound 3 lay 5.9-fold (0.77 log units) above the measured number, and the stated range ends above it.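

In this assay, changing 4-chlorophenoxy to 4-methylphenoxy gives an at least 5.8-fold lower number from compound 2 to compound 3 (0.77 log units; beyond the scatter). This shows that a swap of one heavy atom for another at this position, para to a large group, can move the read-out beyond the scatter. The true size of the step stays open because the value for compound 2 is a limit, not a number: the limit of > 32000 nM in this assay, at which 1 of the 3 values shown sits.

Going by these compounds, whether an amine or a carboxylic acid at this position would lower the number further or raise it remains open. So does whether methyl in place of chloro would act the same way on the core of compound 1.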